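Methyl for Bromo on an Oxathiolane Nucleoside

The source may report more compounds than this note shows. Statements on the series, on what has been measured and on what is new or still open speak of the compounds shown alone.

Compound 1 `OC[C@H]1O[C@H](n2cnc3c(O)ncnc32)CS1`, compound 2 `Nc1nc(=O)n([C@@H]2CS[C@@H](CO)O2)cc1Br` and compound 3 `O=C1NC(O)C(F)=CN1[C@@H]1CS[C@@H](CO)O1` share a sugar-like core carrying different bases. Each was tested in a functional assay on Vero cells (Chlorocebus sabaeus) for inhibition; a lower number here means a stronger inhibitor, a higher number a weaker inhibitor. For compound 1 the result is only a limit, > 100000 nM. For compound 3 the result is likewise only a limit, > 100000 nM. Compound 2 also gives only a limit in this assay, > 100000 nM. Among the measured compounds shown here, compound 2 therefore stands with the whole set at the limit of > 100000 nM in this assay, at which 3 of the 3 values shown sit; no measured compound yet shows a number. Compound 4 `Cc1cn([C@@H]2CS[C@@H](CO)O2)c(=O)nc1N` is the next step, and it differs from compound 2 in a single place: methyl in place of bromo on an aromatic carbon. For the measured compounds named here, every value so far is a limit. Going by the values given here, no measured step between compounds is available to show how much such a change can move the result. The expected step from compound 2 to compound 4 in this assay is an at least 1.2-fold lower number from compound 2 to compound 4 (0.09 log units; that floor lies within the scatter), essentially none beyond the scatter. Compound 4 is therefore estimated at 80000 nM, within a range of 5000 nM to 300000 nM.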

Compound 4, half-maximal inhibitory concentration: > 100000 nM
Compound 4 was reported as a limit (the forecaster's own chance of this, stated with the estimate: 65%); at least 1.2-fold (0.09 log units) between middle value and limit.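

Compound 2 and compound 4 each give only a limit in this assay, so no step can be read for methyl in place of bromo: the limit of > 100000 nM in this assay, at which 4 of the 4 values shown sit.
The compounds shown leave open how far this change can move the result, and whether any base on the shared core gives a true number in this assay at all.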